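Phenyl-to-pyridinyl swap on the thiazole of compound 1

The source may report more compounds than this note shows. Statements on the series, on what has been measured and on what is new or still open speak of the compounds shown alone.

Measured so far:
compound 1, `CCOC(=O)c1sc(-c2ccccc2)nc1N1CCC(NCc2ccc(OC)cc2)CC1`: 8.4%
compound 2, `CCOC(=O)c1sc(-c2ccccc2)nc1N1CCC(NCc2ccc(Cl)c(Cl)c2)CC1`: 18.1%

In an ADME assay on RAW264.7 cells (Mus musculus) for cytotoxicity, read by MTT assay, with a stated time of 72 h, tested at 50 uM (on this read-out higher numbers stand for more inhibition at the one concentration tested (going by the name of the read-out) and lower numbers for less inhibition), compound 1 gives 8.4%, and of the two numbers on hand this is the lower one; compound 2 is the only comparator, with the step of a number 9.7 percentage points higher from compound 1 to compound 2 (within the scatter), so the two compounds are not separated beyond the scatter.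

Compound 3, `CCOC(=O)c1sc(-c2ccccn2)nc1N1CCC(NCc2ccc(OC)cc2)CC1`, is not yet measured. It differs from compound 1 in one place: pyridin-2-yl in place of phenyl on an aromatic carbon. Within the data shown here, the only measured step concerns the group on the saturated chain carbon bound to the amine nitrogen, the part left untouched here, and no measured pair varies the aryl group on the five-membered ring. Among the measured compounds shown here, there is therefore no step that bears directly on this change, and the one step that does exist, from compound 1 to compound 2, stayed within the scatter.

For compound 3 the expected step in this assay is a number 1.6 percentage points higher from compound 1 to compound 3 (within the scatter), that is, no change beyond the scatter. The estimate for compound 3 is 10%, with a range from -4% to 24%.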

Compound 3, a percentage reported as inhibition, at one concentration (the size of the read-out at that concentration, not a potency): 4.62%
Compound 3: the middle estimate sits 5.4 percentage points above what was measured; the measured number falls inside the stated range.
By their numbers in this assay, from the lowest: compounds 3, 1 and 2 (each within the scatter of the next, the first and the last beyond it).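

Pyridin-2-yl in place of phenyl, on an aromatic carbon next to the ring nitrogen and next to the ring sulfur, is the first change measured at this position, and in this assay it gives a number 3.8 percentage points lower from compound 1 to compound 3 (within the scatter). At this one concentration, then, exchanging a ring carbon for a nitrogen in this aryl group, which adds one hydrogen-bond acceptor by count, does not separate the two compounds beyond the usual scatter, so this position has so far shown no sensitivity to the change. Nothing on hand accounts for this result or assigns a measured property to either ring.

As far as these compounds go, it remains open whether the same holds for pyridin-3-yl or pyridin-4-yl, or for a phenyl ring carrying an amine or a carboxylic acid, since a single swap says little about the position as a whole. Also open, from the compounds shown here alone, is whether pyridin-2-yl behaves the same way when paired with the 3,4-dichlorophenyl group in place of the 4-methoxyphenyl group on the amine side of the molecule.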